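Changing the Four-Membered Ring Group: Expected Solubility

The source may report more compounds than this note shows. Statements on the series, on what has been measured and on what is new or still open speak of the compounds shown alone.

Of the compounds shown here, two have so far been measured in a physicochemical assay for solubility, at pH 7.4; a lower number here means a less soluble compound, a higher number a more soluble compound. Compound 1 `C[C@H]1[C@H](N)CN1c1c(F)cc2c(=O)c(C(=O)O)cn(C3CC3)c2c1Cl` gives 12 ug/mL. Compound 2 `CNC1CN(c2c(F)cc3c(=O)c(C(=O)O)cn(C4CC4)c3c2F)C1` gives 1.7 ug/mL, the lower of the two numbers; its gap to compound 1 is larger than the scatter of repeated measurements, so compound 2 stands as the less soluble of the pair.

Compound 3 `C[C@H]1N(c2c(F)cc3c(=O)c(C(=O)O)cn(C4CC4)c3c2F)C[C@]1(C)N` has not yet been measured. It differs from compound 2 at a single place on the shared core: a group of 7 heavy atoms (5 carbon, 2 nitrogen; one four-membered non-aromatic ring with 1 hetero atom) in place of a group of 6 heavy atoms (4 carbon, 2 nitrogen; one four-membered non-aromatic ring with 1 hetero atom), on an aromatic carbon. The group that enters keeps a four-membered non-aromatic ring with one hetero atom and the same hydrogen-bond donor and acceptor counts, and it carries two defined stereocentres.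

Going by the values given here, no measured pair in this set shows what such a change does in this assay, so the expectation rests on the two values alone. Only a small step is expected, a 1.8-fold higher number from compound 2 to compound 3 (0.25 log units; within the scatter), likely within or close to the scatter. Compound 3 is therefore expected to give 3 ug/mL, within a range from 1 ug/mL to 10 ug/mL.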

Compound 3, solubility: 3.3 ug/mL
For compound 3 the middle estimate is 1.1-fold (0.04 log units) below the measured one; low and high end bracket the measured number.
By their numbers in this assay, from the lowest: compounds 2 and 3 (each within the scatter of the next); then compound 1.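

Going by these compounds alone, at this aromatic carbon, ortho to two fluoro groups, the 3-(methylamino)azetidin-1-yl group was exchanged for a group that keeps the four-membered non-aromatic ring with 1 hetero atom and carries 2 defined stereocentres, and in this assay this gives the first single-place comparison in the set (a 1.9-fold higher number from compound 2 to compound 3 (0.29 log units; within the scatter)). A step of this size does not separate the two compounds, so this pair gives no sign that the exchange matters for the read-out, even though the entering group is larger and has defined stereochemistry. Nothing measured alongside these numbers speaks to why the two compounds sit so close together.

All the groups shown at this carbon are built on a four-membered ring, so it remains open what a piperazine or a pyrrolidine at the same place would do in this assay. Also open, from the compounds shown here alone, are whether the other stereoisomers of the entering group would read the same and whether this exchange would give a similar step on the core of compound 1, which carries a chloro group where compounds 2 and 3 carry a fluoro group.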